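The source may hold more compounds than are shown below. What is called first, only, known or untested is meant among the compounds shown, and "the series" means these compounds.

Working notes on the series. Compound 1 `COc1ccccc1N1CCN(CCCNC(=O)NN(Cc2ccccc2)c2ccc(Cl)cc2Cl)CC1` gives 15 nM in an assay on CHO cells for displacement of a labelled ligand from D(4) dopamine receptor (Homo sapiens), read by radioligand binding; on this read-out lower numbers stand for stronger inhibition and higher numbers for weaker inhibition. Compound 2 `COc1ccccc1N1CCN(CCCNC(=O)NN(Cc2ccc(C#N)cc2)c2ccc(Cl)cc2Cl)CC1` gives 12 nM in this assay, and the step of a 1.3-fold lower number from compound 1 to compound 2 (0.10 log units; within the scatter) is the only measured one so far; compound 2 and compound 1 therefore sit within the scatter of one another, and neither can be called the stronger binder on these numbers.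

The next compound, compound 3 `COc1ccc(N(Cc2ccc(C#N)cc2)NC(=O)NCCCN2CCN(c3ccccc3OC)CC2)cc1`, differs from compound 2 by 4-methoxyphenyl in place of 2,4-dichlorophenyl on an amine nitrogen. Within the data shown here, no measured step touches this position: the one step recorded, a 1.3-fold lower number from compound 1 to compound 2 (0.10 log units; within the scatter), concerns a substituent on the benzyl ring and not the aryl group on the amine nitrogen, so it gives no direct guide to the size or direction of the present change. Among the measured compounds shown here, the only inference available is that the single change tried so far stayed within the scatter, which says nothing about a swap of the whole aryl group.

With that reservation, compound 3 is expected to give 30 nM in this assay, within a range of 10 nM to 100 nM. This expectation amounts to a step of a 2.5-fold higher number from compound 2 to compound 3 (0.40 log units; beyond the scatter).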

Compound 3, inhibition constant: 16 nM
Compound 3: middle estimate off by 1.9-fold (0.27 log units), on the high side, and the stated range covers the measured number.
By their numbers in this assay, from the lowest: compounds 2, 1 and 3 (each within the scatter of the next).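

Among these compounds, on the amine nitrogen, 4-methoxyphenyl in place of 2,4-dichlorophenyl gives a 1.3-fold higher number from compound 2 to compound 3 (0.12 log units; within the scatter) in this assay and so provides the first reading at a position that no earlier step touched: the whole aryl group is exchanged here, and the number stays within the scatter. The two groups match in heavy-atom count, while the entering group carries oxygen and a hydrogen-bond acceptor in place of two chlorines, and on this read-out that exchange cannot be told apart from the scatter. Nothing at hand gives a reason for this outcome, which stands as an observation from a single pair of compounds.

Open, on these data alone, is whether this position stays as flat for groups of a different kind on the amine nitrogen, such as a cyclohexyl ring, a pyridine ring or an aryl ring carrying a carboxylic acid or an amine. Also open, as far as these compounds go, is whether 4-methoxyphenyl gives a similar number when the benzyl ring lacks the nitrile, and whether either aryl group behaves the same way with a longer chain leading to the piperazine.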